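The compounds below may be only part of what the source reports. "The series", "measured", "known", "first", "only" and "open" are said of these compounds alone.

Series notes, cyclic triazole set. In a functional assay on HepG2 cells (Homo sapiens) for antiproliferative activity, read by MTT assay, with a stated time of 48 h (on this read-out lower numbers stand for stronger inhibition and higher numbers for weaker inhibition), compound 3 `CCOc1ccccc1-n1nncc1CN1C(=O)C2(C(C#N)=C(N)Oc3c(N)cc4nc5ccccc5nc4c32)c2ccccc21` gives 30500 nM, the lowest of the two numbers shown, though a 1.1-fold lower number from compound 2 to compound 3 (0.04 log units; within the scatter) does not set it apart from compound 2 `N#CC1=C(N)Oc2c(N)cc3nc4ccccc4nc3c2C12C(=O)N(Cc1cnnn1-c1ccccc1Cl)c1ccccc12`, which gives 33500 nM. Compound 1 `Cc1cccc(-n2nncc2CN2C(=O)C3(C(C#N)=C(N)Oc4c(N)cc5nc6ccccc6nc5c43)c3ccccc32)c1` returns only a limit of this assay, > 50000 nM. The two steps from that limit, an at least 1.4-fold lower number from compound 1 to compound 2 (0.17 log units; that floor lies within the scatter) and an at least 1.6-fold lower number from compound 1 to compound 3 (0.21 log units; that floor lies within the scatter), are therefore floors rather than sizes. Compound 4 `N#CC1=C(N)Oc2c(N)cc3nc4ccccc4nc3c2C12C(=O)N(Cc1cnnn1-c1cc(Cl)ccc1Cl)c1ccccc12` is the next member: 2,5-dichlorophenyl in place of 2-ethoxyphenyl on an aromatic nitrogen. The swaps so far among aryl substituents on this nitrogen have stayed within the scatter, so no step beyond the scatter is expected in this assay, a 1.0-fold lower number from compound 3 to compound 4 (0.01 log units; within the scatter). Compound 4 is estimated at 30000 nM, within 12000 nM to 80000 nM.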

Compound 4, half-maximal inhibitory concentration: 33100 nM
For compound 4 the middle estimate is 1.1-fold (0.04 log units) below the measured one, within the range that was stated.
By their numbers in this assay, from the lowest: compounds 3, 4 and 2 (each within the scatter of the next). At a limit, above all of these: compound 1.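

Two further swaps on the aromatic nitrogen leave this assay without a readable change: a 1.1-fold higher number from compound 3 to compound 4 (0.04 log units; within the scatter) for 2,5-dichlorophenyl replacing 2-ethoxyphenyl, and a 1.0-fold lower number from compound 2 to compound 4 (0.01 log units; within the scatter) for the added chloro. New here is that an aryl group with two substituents on this nitrogen stays level with the single-substituent aryl groups of compound 2 and compound 3. The remaining step, an at least 1.5-fold lower number from compound 1 to compound 4 (0.17 log units; that floor lies within the scatter), is only a floor and cannot be read as a size: the limit of > 50000 nM in this assay, at which 1 of the 4 values shown sits.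

From the compounds shown here alone, whether an amine or a carboxylic acid on this aryl group, or a longer alkyl chain in its place, would give a step beyond the scatter stays open.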